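The source may report more compounds than this note shows. Statements on the series, on what has been measured and on what is new or still open speak of the compounds shown alone.

Three measured compounds set the scene. Compound 1 `CCOc1ccccc1-c1ccc(-c2nc(NC(C)C(=O)O)c3ccncc3n2)cc1` gives 2.1 in a physicochemical assay for lipophilicity, read by HPLC, at pH 7.5; a lower number here means a more polar compound, a higher number a more lipophilic compound. Compound 2 `CC[C@@H](Nc1c(C#N)c(-c2ccc(-c3cccnc3C)cc2)nc2cnccc12)C(N)=O` gives 1.9 in this assay, and compound 3 `CC[C@H](Nc1c(C#N)c(-c2ccc(Br)cc2)nc2cnccc12)C(N)=O` gives 2.3. Compound 2 thus holds the lowest of the three numbers; its gap to compound 1 lies within the scatter of repeated measurements, while its gap to compound 3 lies beyond it. Compound 4 `CC[C@@H](Nc1c(C#N)c(-c2ccc(-c3cccc(Cl)c3)cc2)nc2cnccc12)C(N)=O` has not yet been measured. It differs from compound 2 in one place: 3-chlorophenyl in place of 2-methylpyridin-3-yl on an aromatic carbon. Among the compounds with values here, no step between measured compounds matches this change, so no measured precedent guides the step. One expects an upward step, beyond the scatter, of a number 1.30 log units higher from compound 2 to compound 4 (beyond the scatter) in this assay. For compound 4 the estimated value in this assay is 3.2, between 2.6 and 3.8.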

Compound 4, distribution coefficient: 3.1
The estimate for compound 4 lay 0.10 log units above the measured number; the range from low to high includes it.
By their numbers in this assay, from the lowest: compounds 2, 1 and 3 (each within the scatter of the next, the first and the last beyond it); then compound 4.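

Putting 3-chlorophenyl in place of 2-methylpyridin-3-yl on an aromatic carbon, para to a large group, gives in this assay a number 1.20 log units higher from compound 2 to compound 4 (beyond the scatter). Within the data shown here, this is the first one-place comparison here, and it shows that this position can shift the reading strongly even though the two groups have the same heavy-atom count, with the entering group carrying no hydrogen-bond acceptor. Nothing measured accounts for the size of this step. From the compounds shown here alone, how an unsubstituted phenyl, or a phenyl bearing an amine or a carboxylic acid, would read at this position remains open. So does whether the same swap gives a similar step on another core.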